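Methoxyphenyl in Place of Chlorophenyl: Expected Antiproliferative Shift

The source may hold more compounds than are shown below. What is called first, only, known or untested is meant among the compounds shown, and "the series" means these compounds.

Of the compounds shown here, three built on one shared core have been measured in a functional assay on M21 cells (Homo sapiens) for antiproliferative activity, read by sulforhodamine B assay, with a stated time of 48 h; on this read-out lower numbers stand for stronger inhibition of growth and higher numbers for weaker inhibition of growth. Compound 1 `Cc1ccc(-c2cc(N3CCC(CNS(N)(=O)=O)CC3)ncn2)cc1` gives 71000 nM. Compound 2 `COc1ccc(-c2cc(N3CCC(CNS(N)(=O)=O)CC3)ncn2)cc1` reaches only a limit of the assay, > 100000 nM, the limit described by the limit of > 100000 nM in this assay, at which 1 of the 3 values shown sits. Compound 3 `NS(=O)(=O)NCC1CCN(c2cc(-c3cccc(Cl)c3)ncn2)CC1` gives 62500 nM, the lowest of the two numbers shown, though its nearest neighbour is close: a 1.1-fold lower number from compound 1 to compound 3 (0.06 log units; within the scatter), which is within the scatter.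

Compound 4 `COc1ccccc1-c1cc(N2CCC(CNS(N)(=O)=O)CC2)ncn1` differs from compound 3 by 2-methoxyphenyl in place of 3-chlorophenyl on an aromatic carbon. Among the measured compounds shown here, two measured steps bear on this change. First, an at least 1.4-fold higher number from compound 1 to compound 2 (0.14 log units; that floor lies within the scatter), where a methoxy entered in place of a methyl and the number rose to the limit. Second, an at least 1.6-fold lower number from compound 2 to compound 3 (0.20 log units; that floor lies within the scatter), where a chlorophenyl replaced a methoxyphenyl and a number below the limit returned. Both floors lie within the scatter, yet both point the same way: the methoxyphenyl compound sits at the limit while the methyl and chloro compounds give numbers. For this assay a modestly higher number is therefore expected for compound 4, with a real chance that only the limit is reported again.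

Compound 4 is estimated at 100000 nM, within a range from 45000 nM to 250000 nM. That estimate corresponds to the expected step of a 1.6-fold higher number from compound 3 to compound 4 (0.20 log units; within the scatter).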

Compound 4, concentration for 50% growth inhibition: > 100000 nM
Compound 4 was reported as a limit; the forecaster's own chance of this, stated with the estimate: 45%; the middle value sits exactly at the limit.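

In this assay, the 2-methoxyphenyl group in compound 4 gives the same outcome as the 4-methoxyphenyl group in compound 2, so among these compounds the result at the limit is not confined to a single methoxyphenyl placement: the limit of > 100000 nM in this assay, at which 2 of the 4 values shown sit.

Replacing the 3-chlorophenyl group gives an at least 1.6-fold higher number from compound 3 to compound 4 (0.20 log units; that floor lies within the scatter), and replacing the 4-methylphenyl group gives an at least 1.4-fold higher number from compound 1 to compound 4 (0.14 log units; that floor lies within the scatter), so the two methoxyphenyl compounds fall on the same side of the compounds that return numbers, but neither floor establishes a change beyond the scatter. The step between compound 2 and compound 4 cannot be read, leaving the 2-methoxyphenyl and 4-methoxyphenyl groups unranked against each other.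

From the compounds shown here alone, how far the growth-inhibition numbers of compound 2 and compound 4 lie past the limit remains open, as does whether either group truly differs from the 3-chlorophenyl or 4-methylphenyl group. Also open, going by these compounds, is whether an amine or a carboxylic acid on this phenyl ring would move the number clearly beyond the scatter from those of compound 1 and compound 3.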